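The source may report more compounds than this note shows. Statements on the series, on what has been measured and on what is new or still open speak of the compounds shown alone.

Three compounds have been measured in a functional assay for antagonist activity at Alpha-1A adrenergic receptor (Oryctolagus cuniculus); on this read-out higher numbers stand for weaker binding and lower numbers for tighter binding:

Compound 1, `CN(C)C(=O)c1cccnc1NCCCN1CCN(c2ccccc2C#N)CC1`, gives 2 nM.
Compound 2, `CN(C)C(=O)c1cccnc1NCCCN1CCN(c2ccccc2O)CC1`, gives 5.01 nM.
Compound 3, `CN(C)C(=O)c1cccnc1NCCCN1CCN(c2ccccc2OCC(F)(F)F)CC1`, gives 0.1 nM.

All three share one core and differ only in the group on the aromatic ring attached to the piperazine. Compound 3 stands lowest of the three in this assay: the step of a 20-fold lower number from compound 1 to compound 3 (1.30 log units; beyond the scatter) and the step of a 50-fold lower number from compound 2 to compound 3 (1.70 log units; beyond the scatter) are both large and beyond the scatter, while a 2.5-fold higher number from compound 1 to compound 2 (0.40 log units; beyond the scatter) is modest.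

Compound 4, `CN(C)C(=O)c1cccnc1NCCCN1CCN(c2ccccc2OCC2CC2)CC1`, has not yet been measured. It differs from compound 3 by one change: cyclopropyl in place of trifluoromethyl on a saturated chain carbon bound to an oxygen on an aromatic ring. Among the compounds with values here, no measured step changes this part of the molecule, so there is no direct precedent. The two large steps to compound 3 show that an alkoxy group of this kind on the aromatic ring goes with low numbers, and compound 4 keeps an alkoxy group of similar size. A small step, within or near the scatter, is therefore expected for a 2.0-fold higher number from compound 3 to compound 4 (0.30 log units; within the scatter). For compound 4 the estimate in this assay is 0.2 nM, with a range from 0.05 nM to 1 nM.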

Compound 4, dissociation constant: 0.159 nM
Compound 4: the middle estimate sits 1.3-fold (0.10 log units) above what was measured; the measured number falls inside the stated range.
By their numbers in this assay, from the lowest: compounds 3 and 4 (each within the scatter of the next); then compound 1; then compound 2.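

In this assay, cyclopropyl in place of trifluoromethyl on a saturated chain carbon bound to an oxygen on an aromatic ring gives a step that stays within the scatter (a 1.6-fold higher number from compound 3 to compound 4 (0.20 log units; within the scatter)), so this position accepts a small all-carbon ring as well as the fluorine-bearing group. Fluorine is therefore not required for a large step from the other two compounds: cyclopropylmethyl in place of hydrogen on the oxygen gives one (a 32-fold lower number from compound 2 to compound 4 (1.50 log units; beyond the scatter)), and cyclopropylmethoxy in place of cyano gives another (a 13-fold lower number from compound 1 to compound 4 (1.10 log units; beyond the scatter)). No measured evidence here explains why the two groups give numbers within the scatter of each other.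

As far as these compounds go, how much further this position can be changed remains open. A larger ring such as cyclohexyl, or an amine or carboxylic acid on the same chain carbon, might give a very different number.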